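Furan-2-ylmethyl in Place of Dichlorophenyl: Expected Cytotoxicity

This account rests on a few compounds, and the source may have more. Where it says the series, first, only, none or still open, it means among the compounds named here.

Compound 2 `O=C(CNc1nc(N2CCCC2)nc2ccccc12)Nc1cc(Cl)cc(Cl)c1` was tested in an ADME assay on HEK-293T cells (Homo sapiens) for cytotoxicity, read by CCK-8 assay, with a stated time of 48 h (on this read-out higher numbers stand for lower toxicity in this test and lower numbers for higher toxicity in this test), and gives 15900 nM. Among the two numbers measured so far, compound 2 has the one at the low end, yet its only neighbour, compound 1 `O=C(CNc1nc(N2CCCC2)nc2ccccc12)Nc1ccccc1`, gives 23300 nM in this assay, and the step of a 1.5-fold lower number from compound 1 to compound 2 (0.17 log units; within the scatter) is within the scatter, so the two compounds are not distinguishable on this read-out.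

Compound 3 `O=C(CNc1nc(N2CCCC2)nc2ccccc12)NCc1ccco1` has not yet been measured in this assay. It differs from compound 2 in one place: (furan-2-yl)methyl in place of 3,5-dichlorophenyl on an amide-type nitrogen. A single measured step exists, and it concerns a different exchange at the same amide-type nitrogen, phenyl against 3,5-dichlorophenyl; there a 1.5-fold lower number from compound 1 to compound 2 (0.17 log units; within the scatter) stayed within the scatter. Going by the values given here, no measured step involves the (furan-2-yl)methyl group itself. Because a 1.5-fold lower number from compound 1 to compound 2 (0.17 log units; within the scatter) did not move the number beyond the scatter, compound 3 is expected to show a 1.3-fold higher number from compound 2 to compound 3 (0.10 log units; within the scatter) in this assay, a step not beyond the scatter. The estimate for compound 3 in this assay is 20000 nM, with a range from 7000 nM to 60000 nM.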

Compound 3, half-maximal cytotoxic concentration: > 100000 nM
Compound 3 was reported as a limit; the forecaster's own chance of this, stated with the estimate: 15%; at least 5.0-fold (0.69 log units) between middle value and limit.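

In this assay, this amide-type nitrogen proves able to move the read-out: the exchange of phenyl for 3,5-dichlorophenyl had stayed within the scatter, while (furan-2-yl)methyl brings an at least 6.2-fold higher number from compound 2 to compound 3 (0.79 log units; beyond the scatter) and an at least 4.2-fold higher number from compound 1 to compound 3 (0.63 log units; beyond the scatter). Both steps point towards lower toxicity in this test, so the group on this nitrogen matters in a way that the first two compounds could not show. The value for compound 3 is a limit of the assay and not a number, so the true size of both steps remains unknown: the limit of > 100000 nM in this assay, at which 1 of the 3 values shown sits.

The compounds shown do not separate the two things that change together here, the five-membered ring with its oxygen and the methyl link that sets the ring off from the nitrogen; a benzyl group on the same nitrogen would tell the link apart from the ring. They also leave open whether the same step would follow with other groups in this place, such as a longer chain ending in an amine or a carboxylic acid.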